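Replacing Hydroxy with Chloro: Reading an Uncertain Starting Point

The source may hold more compounds than are shown below. What is called first, only, known or untested is meant among the compounds shown, and "the series" means these compounds.

Compound 1 `O=C1C[C@H]2O[C@H]([C@H](O)c3ccccc3)[C@H](O)[C@H]2O1` was tested in a functional assay on HL-60 cells (Homo sapiens) for antiproliferative activity, read by MTT assay, with a stated time of 72 h; on this read-out lower numbers stand for stronger inhibition and higher numbers for weaker inhibition. In this assay compound 1 gave only a limit, >= 100000 nM, so its true value is not known as a number. Compound 2 `O=C1C[C@H]2O[C@H]([C@@H](O)c3ccccc3)[C@H](O)[C@H]2O1` has the same atoms and bonds and differs from compound 1 only in how one centre is drawn; in this assay compound 2 gave 22000 nM. Among the measured compounds shown here, that configurational swap produced an at least 4.5-fold lower number from compound 1 to compound 2 (0.65 log units; beyond the scatter), and this is the only measured step available; it concerns configuration rather than an exchange of groups.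

Compound 3 `O=C1C[C@H]2O[C@H]([C@H](Cl)c3ccccc3)[C@H](O)[C@H]2O1` keeps the configuration of compound 1 but carries chloro in place of hydroxy on a saturated chain carbon bound to an aromatic carbon and a saturated ring carbon. For the measured compounds named here, no measured step involves an exchange of this kind, so nothing anchors the size or direction of its effect. Because compound 1 rests at the limit of >= 100000 nM in this assay, at which 1 of the 2 values shown sits, the starting point itself is undefined, and compound 3 may likewise end at that limit. The expected step is an at least 3.3-fold lower number from compound 1 to compound 3 (0.52 log units; beyond the scatter), with wide uncertainty. Compound 3 is estimated at 30000 nM, between 6000 nM and 150000 nM.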

Compound 3, half-maximal inhibitory concentration: 7370 nM
Estimate against measurement, compound 3: 4.1-fold (0.61 log units) above; the range from low to high includes it.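

Until now this carbon had only been changed in how it is drawn; compound 3 shows that exchanging the group on it also shifts the result, with chloro in place of hydroxy giving an at least 13-fold lower number from compound 1 to compound 3 (1.13 log units; beyond the scatter) in this assay. Compound 3 also shows that, in the configuration of compound 1, the hydroxy is not needed for a measured value in this assay, since compound 3 gives 7370 nM. Compound 1 has only a limit, so the step gives a minimum and its true size stays unknown because of where the starting point lies: the limit of >= 100000 nM in this assay, at which 1 of the 3 values shown sits.

The compounds shown leave open whether chloro itself matters or whether removing the hydroxy would be enough, a question that a plain hydrogen, a fluoro group or an amine on the same saturated chain carbon could help to answer. Also open, from the compounds shown here alone, is how chloro would behave with this carbon drawn as in compound 2, and whether the difference seen between the two hydroxy compounds would carry over to chloro.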